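Shrinking the Carbamate Ester from Isopropyl to Methyl

This account rests on a few compounds, and the source may have more. Where it says the series, first, only, none or still open, it means among the compounds named here.

Among the compounds with values here, compound 2 `CC(C)OC(=O)N(O)CCC#Cc1ccc(OCCCCN2CCN(C(c3ccc(F)cc3)c3ccc(F)cc3)CC2)cc1` gives 335 nM in an assay on isolated protein for inhibition of Polyunsaturated fatty acid 5-lipoxygenase (Homo sapiens) (on this read-out lower numbers stand for stronger inhibition and higher numbers for weaker inhibition), one of only two numbers so far; the other belongs to compound 1 `NC(=O)N(O)CCC#Cc1ccc(OCCCCN2CCN(C(c3ccc(F)cc3)c3ccc(F)cc3)CC2)cc1`, which gives 193 nM. Within the data shown here, the single step between them, a 1.7-fold higher number from compound 1 to compound 2 (0.24 log units; within the scatter), came from isopropoxy in place of amino on a carbonyl carbon. Compound 3 `COC(=O)N(O)CCC#Cc1ccc(OCCCCN2CCN(C(c3ccc(F)cc3)c3ccc(F)cc3)CC2)cc1` differs from compound 2 by methyl in place of isopropyl on an oxygen next to a carbonyl group. Among the measured compounds shown here, no measured step covers this exact change, and the only step seen so far stayed within the scatter, so no shift beyond the scatter is expected in this assay. Compound 3 is therefore estimated at 300 nM, between 120 nM and 750 nM, a step of a 1.1-fold lower number from compound 2 to compound 3 (0.05 log units; within the scatter).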

Compound 3, half-maximal inhibitory concentration: 170 nM
The estimate for compound 3 lay 1.8-fold (0.25 log units) above the measured number; low and high end bracket the measured number.
By their numbers in this assay, from the lowest: compounds 3, 1 and 2 (each within the scatter of the next).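

In this assay, methyl in place of isopropyl gives a 2.0-fold lower number from compound 2 to compound 3 (0.29 log units; within the scatter) and so shows that this swap on the oxygen leaves the read-out within the scatter. Methoxy in place of amino gives a 1.1-fold lower number from compound 1 to compound 3 (0.06 log units; within the scatter) and so adds a second swap within the scatter, which means amino, isopropoxy and methoxy on this carbonyl carbon cannot be told apart here. No supporting evidence is available to explain these results. Still open, from the compounds shown here alone, is how a longer chain such as butoxy, or a phenoxy group, would read on this carbonyl carbon.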